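The source may report more compounds than this note shows. Statements on the series, on what has been measured and on what is new or still open speak of the compounds shown alone.

In a functional assay on HepG2 cells (Homo sapiens) for inhibition, read by MTT assay (on this read-out lower numbers stand for stronger inhibition and higher numbers for weaker inhibition), three compounds sharing one core have been measured. Compound 1 `COc1cc2ncnc(Nc3ccc(NC(=O)c4ccc(C(C)(C)C)cc4)cc3)c2cc1OC` gives > 100000 nM, which is a limit of the assay and not a number. Compound 2 `COc1cc2ncnc(Nc3ccc(NC(=O)c4cccc(F)c4)cc3)c2cc1OC` gives 8200 nM, and compound 3 `COc1cc2ncnc(Nc3ccc(NC(=O)c4c(F)cccc4F)cc3)c2cc1OC` gives 17000 nM, the higher of the two true numbers. Compound 4 `COc1cc2ncnc(Nc3ccc(NC(=O)c4cc(F)ccc4Br)cc3)c2cc1OC` is still unmeasured, and it differs from compound 3 on a carbonyl carbon: 2-bromo-5-fluorophenyl in place of 2,6-difluorophenyl on a carbonyl carbon. The closest guide is the modest 2.1-fold higher number from compound 2 to compound 3 (0.32 log units; beyond the scatter), where one halogen-bearing phenyl replaced another. The larger at least 12-fold lower number from compound 1 to compound 2 (1.08 log units; beyond the scatter) and an at least 5.8-fold lower number from compound 1 to compound 3 (0.76 log units; beyond the scatter) both removed 4-(tert-butyl)phenyl, which does not happen here. A small step is therefore expected, estimated at a 1.2-fold lower number from compound 3 to compound 4 (0.08 log units; within the scatter), with no clear direction beyond the scatter. Compound 4 is expected to give about 14000 nM, within an estimated range of 5000 nM to 40000 nM.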

Compound 4, half-maximal inhibitory concentration: 22000 nM
The estimate for compound 4 lay 1.6-fold (0.20 log units) below the measured number; measured number inside the range.
By their numbers in this assay, from the lowest: compound 2; then compounds 3 and 4 (each within the scatter of the next). At a limit, above all of these: compound 1.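

Halogen swaps on this phenyl ring now appear to matter little: 2-bromo-5-fluorophenyl and 2,6-difluorophenyl on the carbonyl carbon cannot be told apart (a 1.3-fold higher number from compound 3 to compound 4 (0.11 log units; within the scatter)). Bromo in place of hydrogen on an aromatic carbon brings no gain (a 2.7-fold higher number from compound 2 to compound 4 (0.43 log units; beyond the scatter)). The 4-(tert-butyl)phenyl of compound 1 stays apart (an at least 4.5-fold lower number from compound 1 to compound 4 (0.65 log units; beyond the scatter)), and this step is only a bound because compound 1 stands at a limit of the assay: the limit of > 100000 nM in this assay, at which 1 of the 4 values shown sits.

Going by these compounds, what an amine or a carboxylic acid on this phenyl ring would do remains open. So does a ring carrying bromo with no fluorine.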